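The compounds below may be only part of what the source reports. "The series", "measured", "known", "first", "only" and "open" are said of these compounds alone.

Measured so far:
- compound 1, `CN(C)C(=O)c1cccnc1NCCCN1CCN(c2ccccc2O)CC1` — 63.1 nM
- compound 2, `COc1cc(F)ccc1N1CCN(CCCNc2c(C(=O)N(C)C)c[nH]c3ccn[n+]2-3)CC1` — 100 nM

In a functional assay on aorta for antagonist activity at Alpha-1D adrenergic receptor (Rattus norvegicus) (on this read-out higher numbers stand for weaker binding and lower numbers for tighter binding), compound 2 gives 100 nM. Compound 1 gives 63.1 nM in this assay, and the two values lie within the usual scatter of each other, so neither is separated from the other.

Compound 3, `COc1cc(F)ccc1N1CCN(CCCNc2c(C(=O)N(C)C)c[nH]c3c(Cl)cn[n+]2-3)CC1`, differs from compound 2 by chloro in place of hydrogen on an aromatic carbon. Within the data shown here, no step between measured compounds bears on such a change, so no step beyond the scatter is expected in either direction. Compound 3 is therefore estimated at 80 nM, range 25 nM to 250 nM, an expected step of a 1.3-fold lower number from compound 2 to compound 3 (0.10 log units; within the scatter).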

Compound 3, dissociation constant: 158 nM
Compound 3: middle estimate off by 2.0-fold (0.30 log units), on the low side; the measured number falls inside the stated range.
By their numbers in this assay, from the lowest: compounds 1, 2 and 3 (each within the scatter of the next, the first and the last beyond it).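

Working from this assay, chloro in place of hydrogen on an aromatic carbon of the five-membered aromatic ring gives a 1.6-fold higher number from compound 2 to compound 3 (0.20 log units; within the scatter), so this one change leaves the two compounds unseparated. Compound 2 alone could give no reading of a substituent at this position; this pair gives the first, and it shows that one chlorine atom here produces no step beyond the scatter. No available measurement accounts for the size of this step.

Open, from the compounds shown here alone, is whether fluoro, methoxy or a dimethylamino group at this carbon would also stay within the scatter of compound 2. Also open, going by these compounds, is whether chloro behaves the same way with other groups on the piperazine.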